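Adding a methylimidazole to the benzamide of compound 2

This account rests on a few compounds, and the source may have more. Where it says the series, first, only, none or still open, it means among the compounds named here.

Measured so far:
compound 1, `O=C(Nc1ccc(-n2ccc3c(NC(=O)c4ccccc4)nccc32)cc1)Nc1ccc(Cl)c(C(F)(F)F)c1` — 2400 nM
compound 2, `O=C(Nc1ccc(-n2ccc3c(NC(=O)c4ccccc4)nccc32)cc1)c1cccc(C(F)(F)F)c1` — 100 nM

Within the data shown here, in a functional assay on A-375 cells (Homo sapiens) for antiproliferative activity, read by MTT assay, with a stated time of 48 h, in the presence of a further agent that is not named here (on this read-out lower numbers stand for stronger inhibition and higher numbers for weaker inhibition), compound 2 gives the lowest of the two numbers; the only other compound, compound 1, lies a 24-fold lower number from compound 1 to compound 2 (1.38 log units; beyond the scatter) away. Compound 3, `Cc1cn(-c2cc(C(=O)Nc3ccc(-n4ccc5c(NC(=O)c6ccccc6)nccc54)cc3)cc(C(F)(F)F)c2)cn1`, differs from compound 2 by 4-methyl-1H-imidazol-1-yl in place of hydrogen on an aromatic carbon. Among the measured compounds shown here, the single measured step concerns the linker, not this ring position, so no measured step bears directly on the change. A step of no more than modest size, in either direction, is therefore expected, and the estimate for compound 3 in this assay is 70 nM (range 20 nM to 300 nM), meaning an expected 1.4-fold lower number from compound 2 to compound 3 (0.15 log units; within the scatter).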

Compound 3, half-maximal inhibitory concentration: 800 nM
Beside the measured number, compound 3's estimate is 11-fold (1.06 log units) below it, outside the stated range (above it).
By their numbers in this assay, from the lowest: compound 2; then compound 3; then compound 1.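

Among these compounds, the earlier step concerned only the linker, so this is the first reading on the ring that carries the trifluoromethyl group. In this assay, adding 4-methyl-1H-imidazol-1-yl to that ring gives an 8.0-fold higher number from compound 2 to compound 3 (0.90 log units; beyond the scatter) and so shows that this position is sensitive to a substituent of this size. Nothing measured here explains the loss.

From the compounds shown here alone, whether a smaller group here, such as an amine or a methyl, would keep the number of compound 2 stays open. So does the part played by the methyl on the imidazole.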